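Replacing an Ester-Bearing Carbamate Tail with Trichloroethyl

A few compounds are considered here, and "the series" means these few. Any claim that something is new, unique, unknown or untested is made for them only; others in the source may bear on it.

Compound 2 `CC(OC(=O)C(C)C)OC(=O)N1CCN(C(=O)c2nc(Nc3cc(C4CC4)[nH]n3)c3cc(Cl)ccc3n2)C[C@H]1C` was tested in an assay for inhibition of serine/threonine-protein kinase PAK 4 (Homo sapiens), read by FRET and Z'-LYTE, with a stated time of 60 min, tested at 5 uM, in the presence of a further agent that is not named here (a lower number here means a weaker effect, a higher number a stronger effect of the compound at the concentration tested), and gives 25.8%. Its single companion, compound 1 `CC(OC(=O)N1CCN(C(=O)c2nc(Nc3cc(C4CC4)[nH]n3)c3cc(Cl)ccc3n2)C[C@H]1C)OC(=O)C(C)(C)C`, gives 23.6%, and the two numbers lie within the scatter of each other: a number 2.2 percentage points higher from compound 1 to compound 2 (within the scatter). Compound 3 `C[C@@H]1CN(C(=O)c2nc(Nc3cc(C4CC4)[nH]n3)c3cc(Cl)ccc3n2)CCN1C(=O)OCC(Cl)(Cl)Cl` has not yet been measured. It differs from compound 2 in one place: 2,2,2-trichloroethyl in place of 1-((isopropylcarbonyl)oxy)ethyl on an oxygen next to a carbonyl group. For the measured compounds named here, only one measured step exists, from compound 1 to compound 2, and it also altered the group on this oxygen, yet it stayed within the scatter. Going by the values given here, no step bearing on the full swap to 2,2,2-trichloroethyl has been measured, so the guide is thin. Given that, for compound 3 a step of a number 1.8 percentage points lower from compound 2 to compound 3 (within the scatter) is expected, nothing beyond the scatter. The estimate for compound 3 is therefore 24%, with a range from 8% to 40%.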

Compound 3, a percentage reported as inhibition, at one concentration (the size of the read-out at that concentration, not a potency): 63%
Estimate against measurement, compound 3: 39 percentage points below, outside the stated range (above it).
By their numbers in this assay, from the lowest: compounds 1 and 2 (each within the scatter of the next); then compound 3.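

The group on an oxygen next to a carbonyl group turns out to matter in this assay. Putting 2,2,2-trichloroethyl in place of 1-((isopropylcarbonyl)oxy)ethyl gives a number 37.2 percentage points higher from compound 2 to compound 3 (beyond the scatter), and putting it in place of 1-(((tert-butyl)carbonyl)oxy)ethyl gives a number 39.4 percentage points higher from compound 1 to compound 3 (beyond the scatter), whereas the earlier change within the ester-bearing group stayed within the scatter. No measurement here explains why the trichloroethyl carbamate reads so much higher.

This swap removes the ester-bearing chain and brings in chlorine atoms in one move, so the compounds shown leave open which of these two changes carries the step. A plain ethyl or a 2,2,2-trifluoroethyl on the same oxygen would help separate the two, and a full concentration series would show whether the stronger effect seen at this one concentration holds at others.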